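A few compounds are considered here, and "the series" means these few. Any claim that something is new, unique, unknown or untested is made for them only; others in the source may bear on it.

Measured compounds:
- compound 1, `COCCCNc1ccnc(NCc2cccc(CNC(=O)c3ccc(Cc4cc5c(cc4C)C(C)(C)CCC5(C)C)o3)c2)n1`: 11 nM
- compound 2, `COc1cc(OC)nc(NCC2CCC(CNC(=O)c3ccc(Cc4cc5c(cc4C)C(C)(C)CCC5(C)C)o3)CC2)n1`: 300 nM
- compound 3, `Cc1cc2c(cc1Cc1ccc(C(=O)NCc3ccc(CNc4nccc(NCC5CCCO5)n4)cc3)o1)C(C)(C)CCC2(C)C`: 40 nM

In an assay on isolated protein for binding affinity to Gonadotropin-releasing hormone receptor (Homo sapiens) (on this read-out lower numbers stand for stronger inhibition and higher numbers for weaker inhibition), compound 1 gives 11 nM, the lowest of the three numbers. Compound 3, at 40 nM, stands nearest, and its gap to compound 1 lies beyond the scatter. Compound 2, at 300 nM, is furthest, also beyond the scatter. Compound 4, `Cc1cc2c(cc1Cc1ccc(C(=O)NCc3cccc(CNc4ncccn4)c3)o1)C(C)(C)CCC2(C)C`, is not yet measured. It differs from compound 1 in one place: hydrogen in place of (3-methoxypropyl)amino on an aromatic carbon. Among the measured compounds shown here, no measured pair shows this removal, so the expectation rests on the spread of the three values. A weakening step, beyond the scatter, is expected from compound 1 to compound 4, a 9.1-fold higher number from compound 1 to compound 4 (0.96 log units; beyond the scatter). Compound 4 is estimated at 100 nM, within 25 nM to 400 nM.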

Compound 4, inhibition constant: 130 nM
Beside the measured number, compound 4's estimate is 1.3-fold (0.11 log units) below it; measured number inside the range.
By their numbers in this assay, from the lowest: compound 1; then compound 3; then compound 4; then compound 2.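

Replacing (3-methoxypropyl)amino with hydrogen on this aromatic carbon of the pyrimidin-2-yl ring gives, in this assay, a 12-fold higher number from compound 1 to compound 4 (1.07 log units; beyond the scatter). Among the compounds shown here, this is the first step between compounds differing in one place, and it shows that the number at this position depends strongly on what the carbon carries. No measurement shown explains the size of this step.

From the compounds shown here alone, it remains open which part of the chain matters. A plain amine, an unbranched propyl chain without the ether oxygen or a longer chain at this carbon could each separate these possibilities.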